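Removing a Methyl From an Alkyne-Linked Benzamide

The source may report more compounds than this note shows. Statements on the series, on what has been measured and on what is new or still open speak of the compounds shown alone.

Compound 1 `CCN1CCN(Cc2ccc(NC(=O)c3ccc(C)c(C#Cc4cnc5[nH]ccc5c4)c3)cc2C(F)(F)F)CC1` and compound 2 `CCN1CCN(Cc2ccc(NC(=O)c3ccc(C)c(C#Cc4cnc5[nH]c(C)cc5c4)c3)cc2C(F)(F)F)CC1` share one core, in which an amide links a piperazine-bearing ring to a ring that carries an alkyne. They differ in a single spot: hydrogen in place of methyl on an aromatic carbon. In a functional assay on BaF3 cells (Mus musculus) for antiproliferative activity (on this read-out lower numbers stand for an effect already at smaller amounts and higher numbers for an effect only at larger amounts of compound), compound 2 gives 1000 nM, and in this assay compound 1 gives 1000 nM. The step is no change at the digits printed from compound 2 to compound 1 (within the scatter).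

Compound 3 `Cc1cn(-c2cc(NC(=O)c3ccc(C)c(C#Cc4cnc5[nH]ccc5c4)c3)cc(C(F)(F)F)c2)cn1` is built on a different core; how the core of compound 2 and the core of compound 3 differ is not broken down here. In this assay compound 3 reaches only a limit, > 10000 nM, so no number is known for it. Compound 3 therefore stands at the limit of > 10000 nM in this assay, at which 1 of the 3 values shown sits.

Compound 4 `Cc1cn(-c2cc(NC(=O)c3cccc(C#Cc4cnc5[nH]ccc5c4)c3)cc(C(F)(F)F)c2)cn1` has not yet been measured. It differs from compound 3 by hydrogen in place of methyl on an aromatic carbon. Among the measured compounds shown here, this is the same kind of change as the one from compound 2 to compound 1, but not the same: there the methyl left a five-membered aromatic ring with 1 nitrogen, part of a fused or bridged system of two rings, next to the ring nitrogen; here it leaves a six-membered aromatic ring of carbon only, ortho to a large group and para to a large group. The expected step is a number no higher from compound 3 to compound 4 (the limit leaves the size open). This expectation rests on the measured step of no change at the digits printed from compound 2 to compound 1 (within the scatter). It also rests on compound 3 sitting at the limit > 10000 nM. Compound 4 is therefore expected to give 10000 nM in this assay, with a likely range from 3000 nM to 30000 nM, and a fair chance that only a limit is reported.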

Compound 4, half-maximal effective concentration: 2830 nM
Compound 4: the middle estimate sits 3.5-fold (0.55 log units) above what was measured; the whole stated range lies above it.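

In this assay, putting hydrogen in place of the methyl on the six-membered aromatic ring of carbon only gives an at least 3.5-fold lower number from compound 3 to compound 4 (0.54 log units; beyond the scatter), which means that this kind of change does not carry over with the same size from one core to the other: the same change on two cores in this assay, no change at the digits printed (within the scatter) from compound 2 to compound 1 and an at least 3.5-fold lower number (0.54 log units; beyond the scatter) from compound 3 to compound 4, at least 3.5-fold (0.54 log units) apart, beyond the scatter of two such steps

Compound 3 gives > 10000 nM in this assay, which is a limit and not a number, so the size of the new step is bounded on one side only: the limit of > 10000 nM in this assay, at which 1 of the 4 values shown sits.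

The methyl also leaves a different place in each step, and two steps cannot tell whether that place or the rest of the core sets the gap between them, nor do they give a rule for the whole series.

The compounds shown leave open how a fluorine atom, a chlorine atom or a methoxy group would compare with hydrogen and methyl on that aromatic carbon of the core of compound 4. They also leave open what the same removal of the methyl from the six-membered aromatic ring of carbon only would do in compound 1, where the piperazine-bearing ring would show whether the step seen here carries over.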